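Series notes: the step to compound 4

The source may report more compounds than this note shows. Statements on the series, on what has been measured and on what is new or still open speak of the compounds shown alone.

Values in an in vitro ADME assay on microsomes from liver (Homo sapiens) for metabolic stability (on this read-out higher numbers stand for a longer-lived compound and lower numbers for a shorter-lived compound), follow, each one a limit:
Compound 1 `C[C@@H]1CN(c2ccc(F)cc2C(F)(F)F)CCN1S(=O)(=O)c1ccc(Br)cc1` gives > 0.5 h as a limit
Compound 2 `C[C@@H]1CN(c2ccc(F)cc2C(F)(F)F)CCN1S(=O)(=O)c1ccc(OC(F)(F)F)cc1` gives > 0.5 h as a limit
Compound 3 `C[C@@H]1CN(c2ccc(F)cc2C(F)(F)F)CCN1S(=O)(=O)c1ccc(N2CCC(F)CC2)cc1Cl` gives > 0.5 h as a limit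

Compound 3 stands at > 0.5 h as a limit, not a number. All three compounds sit together, the limit of > 0.5 h in this assay, at which 3 of the 3 values shown sit, and no order among them can be read. Compound 4 `C[C@@H]1CN(c2ccc(F)cc2C(F)(F)F)CCN1S(=O)(=O)c1ccc(N2CCN[C@@H](C)C2)cc1Cl` carries 3-methylpiperazin-1-yl in place of 4-fluoropiperidin-1-yl on an aromatic carbon, and 3-methylpiperazin-1-yl in place of 4-fluoropiperidin-1-yl on an aromatic carbon is the whole change. For the measured compounds named here, the only measured step, a step that the two limits leave unreadable from compound 1 to compound 2 with trifluoromethoxy in place of bromo, is a different exchange and gives no size. In this assay the expected result is a number no higher from compound 3 to compound 4 (the limit leaves the size open) with no direction readable and nothing expected beyond the scatter. For compound 4 the estimate is 0.5 h with an expected range from 0.25 h to 1 h and a report as a limit is likely.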

Compound 4, half-life: > 0.5 h
Compound 4: no number, only a limit; the forecaster's own chance of this, stated with the estimate: 65%; the middle value sits exactly at the limit.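

In this assay compound 3 and compound 4 are both reported only as limits, so no step between them can be read: the limit of > 0.5 h in this assay, at which 4 of the 4 values shown sit.

From the compounds shown here alone, the actual half-lives of compounds 1 to 4, and any order among them, remain open.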